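The source may hold more compounds than are shown below. What is called first, only, known or untested is meant among the compounds shown, and "the series" means these compounds.

Measured so far in an assay on CHO cells for displacement of a labelled ligand from adenosine receptor A2b (Homo sapiens), read by scintillation counting, with a stated time of 75 min, in the presence of a further agent that is not named here; a higher number here means a weaker inhibitor, a lower number a stronger inhibitor:
compound 1 `CCCn1c(=O)c2[nH]c(-c3ccc(S(=O)(=O)N4CCN(c5ccc(Cl)cc5)CC4)cc3)nc2n(CC)c1=O` gives 4.31 nM;
compound 2 `CCCn1c(=O)[nH]c2nc(-c3ccc(S(=O)(=O)N4CCN(c5cccc(Br)c5)CC4)cc3)[nH]c2c1=O` gives 0.234 nM;
compound 3 `CCCn1c(=O)[nH]c2nc(-c3ccc(S(=O)(=O)N4CCN(C)CC4)cc3)[nH]c2c1=O` gives 48.2 nM.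

Compound 1 stands second highest of the three numbers, with compound 3 above it and compound 2 below it, both gaps beyond the scatter. Compound 4 `CCCn1c(=O)c2[nH]c(-c3ccc(S(=O)(=O)N4CCN(c5ccc(Cl)cc5)CC4)cc3)nc2n(C)c1=O` differs from compound 1 by hydrogen in place of methyl on a saturated chain carbon bound to an aromatic nitrogen. Going by the values given here, the only measured step, a 210-fold higher number from compound 2 to compound 3 (2.31 log units; beyond the scatter), changes the group on the amine nitrogen in a ring and does not touch this position, so no step bears directly on the change. With nothing to argue for a shift, compound 4 is expected to sit close to compound 1, with a 1.0-fold higher number from compound 1 to compound 4 (0.02 log units; within the scatter) not beyond the scatter. Compound 4 is therefore estimated at 4.5 nM, between 1.5 nM and 13 nM.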

Compound 4, inhibition constant: 1.91 nM
The estimate for compound 4 lay 2.4-fold (0.37 log units) above the measured number, within the range that was stated.
By their numbers in this assay, from the lowest: compound 2; then compound 4; then compound 1; then compound 3.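

In this assay, the step from ethyl to methyl gives a 2.3-fold lower number from compound 1 to compound 4 (0.35 log units; beyond the scatter), so the group on this aromatic nitrogen affects the number, modestly but beyond the scatter. Going by these compounds alone, the earlier compounds gave no reading here, since their only step, a 210-fold higher number from compound 2 to compound 3 (2.31 log units; beyond the scatter), changes the group on the amine nitrogen in a ring. Nothing offered here accounts for the shift.

On these data alone, whether a butyl chain or a benzyl group at this place would move the number further remains open. So does whether the step from ethyl to methyl would hold with a different group on the amine nitrogen.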